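The source may hold more compounds than are shown below. What is called first, only, known or untested is meant among the compounds shown, and "the series" means these compounds.

Values so far in a functional assay on HCT-116 cells (Homo sapiens) for inhibition; on this read-out higher numbers stand for weaker inhibition and lower numbers for stronger inhibition
compound 1 `CCNC(=O)c1noc(-c2cc(C(C)C)c(O)cc2O)c1-c1cc(COCC(N)=O)no1` gives 97 nM
compound 2 `CCNC(=O)c1noc(-c2cc(C(C)C)c(O)cc2O)c1-c1cc(CNC(=O)CC)no1` gives 78 nM

Going by the values given here, compound 2 stands within the scatter of the only other measured value, so no order is drawn between the two. The next entry is compound 3 `CCNC(=O)c1noc(-c2cc(C(C)C)c(O)cc2O)c1-c1cc(CN2CCCCC2)no1` and the change from compound 2 is piperidin-1-yl in place of propanoylamino on a saturated chain carbon bound to an aromatic carbon in the form of piperidin-1-yl in place of propanoylamino on a saturated chain carbon bound to an aromatic carbon.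

Among the compounds with values here, only one measured step (a 1.2-fold lower number from compound 1 to compound 2 (0.09 log units; within the scatter)) bears on this place, and it stayed within the scatter, so no step beyond the scatter is expected in this assay and neither direction is favoured. That step involved no entering ring, so it is thin evidence for this change and the range is kept wide. The expected step is a 1.1-fold higher number from compound 2 to compound 3 (0.04 log units; within the scatter) and amounts to no real change. For compound 3 the estimated value is 85 nM with an expected range from 30 nM to 250 nM in repeat measurements.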

Compound 3, half-maximal inhibitory concentration: 93 nM
Compound 3: middle estimate off by 1.1-fold (0.04 log units), on the low side; the measured number falls inside the stated range.
By their numbers in this assay, from the lowest: compounds 2, 3 and 1 (each within the scatter of the next).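

In this assay, putting a ring at this place gives a 1.2-fold higher number from compound 2 to compound 3 (0.08 log units; within the scatter), and replacing carbamoylmethoxy with the same ring gives a 1.0-fold lower number from compound 1 to compound 3 (0.02 log units; within the scatter). Propanoylamino, with 1 hydrogen-bond donor, and carbamoylmethoxy can therefore both give way to piperidin-1-yl, a six-membered non-aromatic ring with 0 hydrogen-bond donors, with no step beyond the scatter on a saturated chain carbon bound to an aromatic carbon, and none of the three compounds goes against this reading. No independent measurement is available to explain why these three groups cannot be told apart in this read-out.

Going by these compounds alone, the three compounds show only that these groups fall within the scatter of one another, so they do not define how much variation this place tolerates on the shared core. A carboxylic acid, a primary amine or a longer chain on the same saturated chain carbon would test whether the flat reading extends beyond amide and piperidin-1-yl groups, or whether some group at this place gives a step beyond the scatter.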